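Methyl on the phenol oxygen: from compound 1 to compound 3

A few compounds are considered here, and "the series" means these few. Any claim that something is new, unique, unknown or untested is made for them only; others in the source may bear on it.

Measured so far:
compound 1 `O=C(Nc1cccc(-n2cc(-c3ccncc3)c(-c3cc(O)cc(Cl)c3)n2)c1)Nc1ccc(Cl)c(C(F)(F)F)c1` with -88%
compound 2 `O=C(Nc1cccc(-n2cc(-c3ccncc3)c(-c3cc(O)cc(Cl)c3)n2)c1)Nc1ccc(Cl)c(Cl)c1` with -55%

The read-out here is a functional assay on HCC 2998 cells (Homo sapiens) for inhibition, read by sulforhodamine B assay, with a stated time of 48 h, tested at 100 uM; on this read-out lower numbers stand for a stronger effect and higher numbers for a weaker effect at the one concentration tested. In this assay compound 1 gives -88%, the lowest of the two numbers at hand, while compound 2 gives -55%. Within the data shown here, the single measured step, chloro in place of trifluoromethyl on an aromatic carbon, runs a number 33 percentage points higher from compound 1 to compound 2 (beyond the scatter), a large change at a distant part of the molecule.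

Compound 3 `COc1cc(Cl)cc(-c2nn(-c3cccc(NC(=O)Nc4ccc(Cl)c(C(F)(F)F)c4)c3)cc2-c2ccncc2)c1` has not yet been measured. It differs from compound 1 by methyl in place of hydrogen on an oxygen on an aromatic ring, that is, hydroxy to methoxy on the 3-chloro-5-hydroxyphenyl ring. Among the measured compounds shown here, no measured step touches this oxygen, so the measured pair says nothing about the size or direction of this change, and the large step from trifluoromethyl to chloro sits elsewhere. The expected step is therefore small, a number 8 percentage points higher from compound 1 to compound 3 (within the scatter), with the number staying near that of compound 1. Compound 3 is expected to give about -80% in this assay, within a range from -100% to -50%.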

Compound 3, a percentage reported as activity, at one concentration (the size of the read-out at that concentration, not a potency): -75%
Compound 3: middle estimate off by 5 percentage points, on the low side; low and high end bracket the measured number.
By their numbers in this assay, from the lowest: compound 1; then compound 3; then compound 2.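

Among these compounds, replacing the hydrogen on the phenol oxygen with methyl gives the first reading at this position: in this assay the change yields a number 13 percentage points higher from compound 1 to compound 3 (beyond the scatter). The free hydroxy group is therefore not essential to a strongly negative number, since compound 3 still gives -75%, yet the step lies beyond the scatter, so the oxygen's substituent does register in this read-out. The step is modest, whereas the change elsewhere in the molecule, chloro in place of trifluoromethyl, is large at a number 33 percentage points higher from compound 1 to compound 2 (beyond the scatter), and no measured information explains why the methyl step has the size it does.

The compounds shown leave open whether the higher number follows from losing the hydrogen or from adding the methyl, and whether it would continue to rise with a longer chain on the oxygen, such as ethyl, or with an amine in place of the hydroxy group. They also leave open whether methoxy would produce a step of similar size on the chloro partner, compound 2, where the number is already higher.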